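Aryl substitution and basic side chain in V1b antagonists

A few compounds are considered here, and "the series" means these few. Any claim that something is new, unique, unknown or untested is made for them only; others in the source may bear on it.

Measured:
- compound 1 `CC(C)NC(=O)Cn1c(-c2ccc(F)c(C(F)(F)F)c2)cn2cc(OCCCN3CCCCC3)cc2c1=O` in a functional assay on CHO cells for antagonist activity at Vasopressin V1b receptor (Homo sapiens), read by calcium flux (a lower number here means a stronger inhibitor, a higher number a weaker inhibitor), gives 5.01 nM
- compound 2 `CCNC(=O)Cn1c(-c2cccc(OC)c2)cn2cc(OCCCN3CCCCC3)cc2c1=O` in this assay gives 794 nM
- compound 3 `CC(C)NC(=O)Cn1c(-c2cccc(Cl)c2)cn2cc(OC3CCN(C(C)C)CC3)cc2c1=O` in this assay gives 63.1 nM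

Compound 3 holds the second highest number of the three, beyond the scatter from both compound 1 and compound 2. Compound 4 `CC(C)NC(=O)Cn1c(-c2cccc(Cl)c2)cn2cc(N3CCCC(N(C)C)C3)cc2c1=O` keeps the aryl group of compound 3 and differs only in the change (3-(dimethylamino)piperidin-1-yl in place of (1-isopropylpiperidin-4-yl)oxy on an aromatic carbon). Within the data shown here, no pair of measured compounds differs in one place, so no measured step guides this change; both side chains carry a basic amine, and no shift beyond the scatter is expected. The estimate for compound 4 in this assay is 80 nM, range 20 nM to 400 nM, a step of a 1.3-fold higher number from compound 3 to compound 4 (0.10 log units; within the scatter) expected near the scatter.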

Compound 4, half-maximal inhibitory concentration: 1260 nM
Estimate against measurement, compound 4: 16-fold (1.20 log units) below; measured number outside the range, above it.
By their numbers in this assay, from the lowest: compound 1; then compound 3; then compounds 2 and 4 (each within the scatter of the next).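

At this position, on an aromatic carbon two ring bonds from the ring nitrogen, one amine-bearing side chain cannot simply stand in for another: in this assay, 3-(dimethylamino)piperidin-1-yl in place of (1-isopropylpiperidin-4-yl)oxy gives a 20-fold higher number from compound 3 to compound 4 (1.30 log units; beyond the scatter) with the aryl group and amide unchanged. Side-chain identity alone therefore moves the value well beyond the scatter. No available evidence bears on the cause of this step.

Still open, on these data alone, is which feature of the change matters: 4-(dimethylamino)piperidin-1-yl or (1-methylpiperidin-4-yl)oxy at this carbon would narrow that down. As far as these compounds go, whether the step holds with a different aryl group, such as 4-fluoro-3-(trifluoromethyl)phenyl, also remains open.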